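A few compounds are considered here, and "the series" means these few. Any claim that something is new, unique, unknown or untested is made for them only; others in the source may bear on it.

Compound 1 `COc1cc(/C=C2\CN(C)C/C(=C\c3ccc(Cl)cc3)C2=O)cc(OC)c1`: 11200 nM
Compound 2 `CN1C/C(=C\c2ccc(F)cc2)C(=O)/C(=C/c2ccc(C#N)cc2)C1`: 10200 nM

Among the measured compounds shown here, compound 2 gives 10200 nM in a functional assay on HeLa cells (Homo sapiens) for cytotoxicity, read by MTT assay, with a stated time of 24 h (a lower number here means a stronger inhibitor, a higher number a weaker inhibitor), and sits within the scatter of compound 1, the only other compound measured, so the two cannot be told apart. Compound 3 `CN1C/C(=C\c2ccc(Br)cc2)C(=O)/C(=C/c2ccc(C#N)cc2)C1` keeps everything in compound 2 except one group: bromo in place of fluoro on an aromatic carbon. For the measured compounds named here, no measured pair shows such a swap, so the only guide is compound 2 at 10200 nM, and no step beyond the scatter is expected in this assay. The estimated step of a 1.1-fold lower number from compound 2 to compound 3 (0.05 log units; within the scatter) is therefore small. Compound 3 is expected to read 9000 nM, within an estimated range of 4000 nM to 20000 nM once measured.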

Compound 3, half-maximal inhibitory concentration: 5900 nM
Estimate against measurement, compound 3: 1.5-fold (0.18 log units) above; the range from low to high includes it.
By their numbers in this assay, from the lowest: compounds 3, 2 and 1 (each within the scatter of the next).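

Among the compounds shown here, compound 2 and compound 3 give the first comparison that differs in one place. In this assay, going from 4-fluorophenyl to 4-bromophenyl gives a 1.7-fold lower number from compound 2 to compound 3 (0.24 log units; within the scatter) so at this position on the aromatic ring the two halogens cannot be told apart. Nothing measured here offers a reason for this result. On these data alone, whether an amine or a carboxylic acid at this position would move the number beyond the scatter remains open, as does what replacing the nitrile would do.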